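The source may report more compounds than this note shows. Statements on the series, on what has been measured and on what is new or still open speak of the compounds shown alone.

In a functional assay on A-375 cells (Homo sapiens) for antiproliferative activity, read by MTT assay, with a stated time of 72 h (a lower number here means a stronger inhibitor, a higher number a weaker inhibitor), three compounds built on a shared core have been measured, and none of them is strong. Compound 2 `O=C1COc2ccc(-c3cccc(NS(=O)(=O)c4ccc(F)cc4)c3)cc2N1`, which carries the amide hydrogen on the ring nitrogen, gives 20100 nM. Compound 3 `COc1cccc(N2C(=O)COc3ccc(-c4cnc5ccccc5c4)cc32)c1` gives 23600 nM, so compound 3 lies within the usual scatter of compound 2. Compound 1 `O=C1COc2ccc(-c3cnc(Cl)c(NS(=O)(=O)c4ccc(F)cc4)c3)cc2N1C1CCCCC1` reads > 40000 nM, which is a limit of the assay and not a number.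

Compound 4 `COc1cccc(N2C(=O)COc3ccc(-c4cccc(NS(=O)(=O)c5ccc(F)cc5)c4)cc32)c1` keeps the sulfonamide side of compound 2 and changes one place: 3-methoxyphenyl in place of hydrogen on an amide-type nitrogen in a ring. Among the compounds with values here, no measured pair isolates this change. Compound 3 has the same 3-methoxyphenyl group and reaches 23600 nM, which suggests the group is tolerated, though it offers no direct evidence of a gain. A modest move towards stronger inhibition is expected, with an estimated step of a 2.2-fold lower number from compound 2 to compound 4 (0.35 log units; beyond the scatter). For compound 4 the estimated value is 9000 nM, within an expected range of 1800 nM to 40000 nM.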

Compound 4, half-maximal inhibitory concentration: > 40000 nM
Compound 4 gave a limit, no number (the forecaster's own chance of this, stated with the estimate: 20%); middle value at least 4.4-fold (0.64 log units) from the limit.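

In this assay, within the data shown here, 3-methoxyphenyl in place of hydrogen on the amide-type nitrogen in a ring gives an at least 1.9-fold higher number from compound 2 to compound 4 (0.29 log units; that floor lies within the scatter), the first direct reading of this change at this position. It shows no gain in inhibition from the group, although the floor of the step does not establish a real loss either. Because the reading for compound 4 is a limit and not a number, the true size of the step cannot be read: the limit of > 40000 nM in this assay, at which 2 of the 4 values shown sit.

What the compounds shown leave open is whether any other group on this nitrogen would move compound 2 to a lower number. Methyl, or a longer chain ending in an amine or a carboxylic acid, could test whether this position can bring a gain at all.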